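Working notes on cell toxicity across one matched series

The compounds below may be only part of what the source reports. "The series", "measured", "known", "first", "only" and "open" are said of these compounds alone.

Measured compounds:
Compound 1 `COc1cc(C)cc(-c2c(-c3ccnc(-c4ccc(C(C)=O)cc4)c3)cnn2CC#N)c1` — in a functional assay on K562 cells (Homo sapiens) for inhibition, read by sulforhodamine B assay, with a stated time of 48 h (on this read-out higher numbers stand for lower toxicity in this test and lower numbers for higher toxicity in this test), compound 1 gives > 100000 nM, a limit of the assay.
Compound 2 `COc1cc(C)cc(-c2nn(CC#N)cc2-c2ccc(-c3cccc(C(C)=O)c3)nc2)c1` — in this assay compound 2 gives > 100000 nM, again a limit.
Compound 3 `Cc1cc(O)cc(-c2nn(CC#N)cc2-c2ccnc(-c3ccc(Oc4ccccc4)cc3)c2)c1` — in this assay compound 3 gives > 100000 nM, also a limit.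

Compound 3 therefore stands at the assay limit, where every shown value sits (the limit of > 100000 nM in this assay, at which 3 of the 3 values shown sit). Going by the values given here, no pair of measured compounds differs in only one place, so no measured step is available.

Compound 4 `Cc1cc(O)cc(-c2nn(CC#N)cc2-c2ccnc(-c3ccc(N(C)C)cc3)c2)c1` is the next compound to be tested. Relative to compound 3 the change is dimethylamino in place of phenoxy on an aromatic carbon, with dimethylamino in place of phenoxy on an aromatic carbon.

With all three shown values at the limit, the step of a number no higher from compound 3 to compound 4 (the limit leaves the size open) is expected to be none beyond the scatter. Compound 4 is expected to return 100000 nM, within 40000 nM to 300000 nM, most likely again only as a limit.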

Compound 4, concentration lethal to 50% of the cells: > 100000 nM
Compound 4: no number, only a limit (the forecaster's own chance of this, stated with the estimate: 80%); the middle value sits exactly at the limit.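

The step between compound 3 and compound 4 cannot be read because both values are limits: the limit of > 100000 nM in this assay, at which 4 of the 4 values shown sit.

The compounds shown leave open whether any of them reaches a measurable value, and whether dimethylamino and phenoxy differ at all on this read-out.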